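Nitro for hydrogen on the core of compound 1

The source may report more compounds than this note shows. Statements on the series, on what has been measured and on what is new or still open speak of the compounds shown alone.

Compound 1 `CCn1c(/C=C2/C(=O)Nc3ccccc32)nc2ccccc21` is the parent of this pair. Within the data shown here, in a functional assay on A549 cells (Homo sapiens) for cytotoxicity, read by MTT assay, with a stated time of 48 h (on this read-out lower numbers stand for stronger inhibition and higher numbers for weaker inhibition), compound 1 gives > 50000 nM, which is a limit of the assay and not a number, so compound 1 stands at the weak end of what is recorded here; the one firm value belongs to compound 2 `CC(C)n1c(/C=C2/C(=O)Nc3ccc(F)cc32)nc2ccccc21`, which in this assay gives 28500 nM. Compound 3 `CCn1c(/C=C2/C(=O)Nc3ccc([N+](=O)[O-])cc32)nc2ccccc21` is not yet measured. It differs from compound 1 by nitro in place of hydrogen on an aromatic carbon. Among the measured compounds shown here, no measured step between two compounds differing in one place exists, and the only evidence at hand is the limit of > 50000 nM in this assay, at which 1 of the 2 values shown sits, so the size of the step cannot be read from data. The expectation is a modest gain or none beyond the scatter, with a real chance that compound 3 again returns only a limit. For compound 3 the estimate in this assay is 30000 nM, between 8000 nM and 100000 nM, which as a step means an at least 1.6-fold lower number from compound 1 to compound 3 (0.22 log units; that floor lies within the scatter).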

Compound 3, half-maximal inhibitory concentration: > 50000 nM
Compound 3: only a limit was reported (the forecaster's own chance of this, stated with the estimate: 45%); at least 1.6-fold (0.22 log units) between middle value and limit.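

Compound 1 and compound 3 each return only a limit in this assay, so the step between them cannot be read: the limit of > 50000 nM in this assay, at which 2 of the 3 values shown sit.

The compounds shown leave open whether nitro in place of hydrogen on the core of compound 1 changes the read-out at all, and in which direction.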